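The compounds below may be only part of what the source reports. "The series", "measured", "known", "first", "only" and "open" are said of these compounds alone.

Compound 2 `CONc1nc(C#CCCCC#N)nc2c1ncn2[C@@H]1O[C@H](CO)[C@@H](O)[C@H]1O` and compound 1 `CCC(=O)[C@H]1O[C@@H](n2cnc3c(N)nc(C#Cc4ccccc4)nc32)[C@H](O)[C@@H]1O` share a nucleoside core and were both tested in an assay on CHO cells for displacement of a labelled ligand from adenosine receptor A3 (Homo sapiens); a higher number here means a weaker inhibitor, a lower number a stronger inhibitor. In this assay compound 2 gives 4.1 nM, the lower of the two numbers, while compound 1 gives 7.3 nM; the two values lie within the scatter of each other, so neither can be called the stronger binder on this evidence. Compound 3 `CONc1nc(C#CCC(C)O)nc2c1ncn2[C@@H]1O[C@H](CO)[C@@H](O)[C@H]1O` has not yet been measured. It differs from compound 2 in one place, (1-hydroxyethyl in place of 2-cyanoethyl on a saturated chain carbon bound to a triple-bonded carbon), with a hydroxyl group taking the place of the nitrile on the chain attached to the alkyne. Among the compounds with values here, no measured pair shows this exchange, so the step from compound 2 to compound 3 is expected to be small, a 1.5-fold higher number from compound 2 to compound 3 (0.17 log units; within the scatter), most likely within the scatter and without a clear direction. Compound 3 is therefore estimated at 6 nM in this assay, with a range from 1.5 nM to 25 nM.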

Compound 3, inhibition constant: 5.4 nM
For compound 3 the middle estimate is 1.1-fold (0.05 log units) above the measured one; low and high end bracket the measured number.
By their numbers in this assay, from the lowest: compounds 2, 3 and 1 (each within the scatter of the next).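

In this assay, within the data shown here, putting 1-hydroxyethyl in place of 2-cyanoethyl on a saturated chain carbon bound to a triple-bonded carbon gives a 1.3-fold higher number from compound 2 to compound 3 (0.12 log units; within the scatter) and so provides the first measured exchange at this place, one that lies within the scatter. Compound 2 and compound 3 cannot be told apart here, although the group that leaves carries a triple bond and no hydrogen-bond donor, while the group that enters carries a hydrogen-bond donor and no triple bond. No evidence is available that bears on this result.

Still open, on these data alone, is whether an amine, a carboxylic acid or a longer chain carrying the hydroxyl at this place would also stay within the scatter of compound 2 in this assay. Also open, as far as these compounds go, is whether the same exchange would give a similar step on the core of compound 1.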